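The source may report more compounds than this note shows. Statements on the series, on what has been measured and on what is new or still open speak of the compounds shown alone.

Compound 1 `COC(=O)c1ccc(NCc2cncn2Cc2cccc(OC)c2)cc1-c1ccccc1` gives "not determined" (no result reported) in a toxicity assay on NIH3T3 cells (Mus musculus) for cytotoxicity, read by resazurin assay; on this read-out lower numbers stand for an effect already at smaller amounts and higher numbers for an effect only at larger amounts of compound
Compound 2 `COC(=O)c1ccc(NCc2cncn2Cc2cccc(C#N)c2)cc1-c1ccccc1` gives > 10000 nM in this assay

Compound 2 stands at > 10000 nM as a limit of the assay and not a number. Within the data shown here, compound 1 has no result, so the series has no single number so far and no measured step to compare.

Compound 3 `COC(=O)c1ccc(NCc2cncn2Cc2ccccc2[N+](=O)[O-])cc1-c1ccccc1` carries 2-nitrophenyl in place of 3-cyanophenyl on a saturated chain carbon bound to an aromatic nitrogen and keeps the rest of the structure of compound 2.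

In this assay no change beyond the usual scatter is expected, and the expected step that the limit leaves unreadable from compound 2 to compound 3 has no firm direction. This expectation rests only on compound 2 with its limit of > 10000 nM as the one reference point. Another report as a limit is the likeliest outcome. For compound 3 the estimated value is 12000 nM with an expected range of 4000 nM to 30000 nM in this read-out.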

Compound 3, half-maximal effective concentration: 10000 nM
Compound 3: middle estimate off by 1.2-fold (0.08 log units), on the high side; low and high end bracket the measured number.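

Compound 3 gives the series its first single number in this assay, at 10000 nM. Putting 2-nitrophenyl in place of 3-cyanophenyl on a saturated chain carbon bound to an aromatic nitrogen gives a number no higher from compound 2 to compound 3 (the limit leaves the size open), so this position now has one readable value, though not yet a measured effect of the change. The size of the step stays open because compound 2 is reported only as a limit: the limit of > 10000 nM in this assay, at which 1 of the 3 values shown sits.

On these data alone, what an amine or a carboxylic acid on this benzyl ring would give in this assay remains open. Also open, as far as these compounds go, is how much of the reading of compound 3 belongs to the nitro group and how much to its place on the ring, since 3-cyanophenyl and 2-nitrophenyl differ in both.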